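Solubility notes on four compounds of one series

The source may hold more compounds than are shown below. What is called first, only, known or untested is meant among the compounds shown, and "the series" means these compounds.

Measured so far:
Compound 1, `FC(F)(F)c1ccc(-c2ccc3c(NCCCNCc4ccco4)ccnc3c2)cc1`: 32000 nM
Compound 2, `CCC(CC)c1ccc2c(NCCCNCc3cc(F)ccc3OC)ccnc2c1`: 4200 nM
Compound 3, `COc1ccc(F)cc1CNCCCNc1ccnc2cc(Cc3ccccc3)ccc12`: 4200 nM

In a physicochemical assay for solubility, with a stated time of 18 h, at pH 7.4 (on this read-out higher numbers stand for higher solubility and lower numbers for lower solubility), compound 1 gives 32000 nM, the highest of the three values. Compound 2 gives 4200 nM and compound 3 gives 4200 nM, each beyond the scatter below compound 1. Among the compounds with values here, the only single-point step among the measured compounds is no change at the digits printed from compound 2 to compound 3 (within the scatter), and it does not touch the position changed here.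

Compound 4, `COc1ccccc1Oc1ccc2c(NCCCNCc3ccco3)ccnc2c1`, differs from compound 1 in one place: 2-methoxyphenoxy in place of 4-(trifluoromethyl)phenyl on an aromatic carbon. Within the data shown here, no measured step bears on this exchange, so the expectation rests on compound 1 alone and on the groups counted in the change. A moderate rise in solubility is expected, a 1.9-fold higher number from compound 1 to compound 4 (0.27 log units; within the scatter), with wide uncertainty. Compound 4 is estimated at 60000 nM, within 20000 nM to 180000 nM.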

Compound 4, solubility: 14500 nM
Estimate against measurement, compound 4: 4.1-fold (0.62 log units) above; the whole stated range lies above it.
By their numbers in this assay, from the lowest: compounds 2 and 3 (each within the scatter of the next); then compound 4; then compound 1.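

In this assay, this position on the shared core responds to the exchange: 2-methoxyphenoxy in place of 4-(trifluoromethyl)phenyl gives a 2.2-fold lower number from compound 1 to compound 4 (0.34 log units; beyond the scatter). The step is downward although the entering group carries hydrogen-bond acceptors and the leaving group none. Nothing available bears on the reason for this step.

Open, from the compounds shown here alone, is whether the step follows the ether oxygen, the methoxy group or the loss of trifluoromethyl. Also open, going by these compounds, is how a morpholine or a carboxylic acid on this aromatic carbon would read out.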